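The source may report more compounds than this note shows. Statements on the series, on what has been measured and on what is new or still open speak of the compounds shown alone.

Measured compounds in a functional assay on MIA PaCa-2 cells (Homo sapiens) for inhibition, read by MTT assay, with a stated time of 7 days; on this read-out lower numbers stand for stronger inhibition and higher numbers for weaker inhibition:
- compound 1 `CCN(CC)S(=O)(=O)c1ccc(S(=O)(=O)N2CCC[C@@H](C(=O)N3CCC(F)(F)CC3)C2)cc1` gives 16 nM
- compound 2 `O=C([C@@H]1CCCN(S(=O)(=O)c2ccc(S(=O)(=O)N3CC[C@@H](O)C3)cc2)C1)N1CCC(F)(F)CC1` gives 210 nM
- compound 3 `CCN(CC)S(=O)(=O)c1ccc(S(=O)(=O)N2CCC[C@@H](C(=O)N3CCC(O)CC3)C2)cc1` gives 870 nM

Compound 2 holds the middle place of the three, below compound 3 and well above compound 1. The two measured steps both start from compound 1: a 13-fold higher number from compound 1 to compound 2 (1.12 log units; beyond the scatter) on the sulfonyl side, and a 54-fold higher number from compound 1 to compound 3 (1.74 log units; beyond the scatter) on the amide side. Within the data shown here, compound 2 and compound 3 share no single-change step, so their relation is read only from the two values themselves.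

Compound 4 `O=C([C@@H]1CCCN(S(=O)(=O)c2ccc(S(=O)(=O)N3CC[C@H](O)C3)cc2)C1)N1CCC(F)(F)CC1` is the counterpart of compound 2 with the change (the two compounds have the same atoms and bonds and differ only in configuration as drawn: 1 of 2 stereo elements differ; a stereocentre at a saturated ring carbon is drawn R in compound 2 and S in compound 4). Neither measured step concerns a change of configuration; both replace one whole group with another, and they speak only to which group sits on the sulfonyl sulfur or the carbonyl carbon, not to the drawn arrangement at the ring carbon. Among the measured compounds shown here, no step in this set therefore bears directly on the move from compound 2 to compound 4, and no reasoned direction can be set for this assay.

In the absence of any relevant step, compound 4 is expected to stay close to compound 2, with the step of a 1.2-fold higher number from compound 2 to compound 4 (0.08 log units; within the scatter) estimated to lie within the scatter, while the range is kept wide to allow for either direction. Compound 4 is expected to give about 250 nM in this assay, within 70 nM to 900 nM.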

Compound 4, half-maximal inhibitory concentration: 590 nM
Beside the measured number, compound 4's estimate is 2.4-fold (0.37 log units) below it, and the stated range covers the measured number.
By their numbers in this assay, from the lowest: compound 1; then compound 2; then compounds 4 and 3 (each within the scatter of the next).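

In this assay, among these compounds, the drawn configuration at this saturated ring carbon is not neutral, since going from R to S gives a 2.8-fold higher number from compound 2 to compound 4 (0.45 log units; beyond the scatter) and the earlier compounds, which only exchanged whole groups, could not show this. Putting 3-hydroxypyrrolidin-1-yl in place of diethylamino on the sulfonyl sulfur now reads as two steps of different size: a 13-fold higher number from compound 1 to compound 2 (1.12 log units; beyond the scatter) with the R form and a 37-fold higher number from compound 1 to compound 4 (1.57 log units; beyond the scatter) with the S form, so both forms remain far from compound 1 and the R form lies closer to it. The step between the two forms can be tied to this stereocentre alone because no other feature separates them: the fact that compounds 2 and 4 differ only in the configuration as drawn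

Going by these compounds, whether the lower number of the R form persists with a methoxy group or an amine in place of the hydroxy group on that ring carbon stays open. Also open, on these data alone, is how the second stereocentre, drawn alike in compound 2 and compound 4, bears on the read-out, and whether the gap between the two forms survives with 4-hydroxypiperidin-1-yl on the carbonyl carbon.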